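The compounds below may be only part of what the source reports. "The series", "measured", "known", "first", "only" and "open" are said of these compounds alone.

In a physicochemical assay for solubility, in phosphate buffer, measured as kinetic solubility, at pH 7.4 (on this read-out higher numbers stand for higher solubility and lower numbers for lower solubility), compound 1 `Cc1cccc(Cl)c1-c1nc(CN2CCC(C(=O)NCCCN3CCC(C(C)C)CC3)CC2)c(C)o1` gives > 76 ug/mL, which is a limit of the assay and not a number. Within the data shown here, compound 2 `Cc1oc(-c2c(Cl)cccc2C(F)(F)F)nc1CN1CCC(C(=O)NCCCN2C[C@H](C)C[C@H](C)C2)CC1` gives 65.1 ug/mL, the only actual number so far. Compound 3 `COc1cccc(F)c1-c1nc(CN2CCC(C(=O)NCCCN3C[C@H](C)C[C@H](C)C3)CC2)c(C)o1` has 2-fluoro-6-methoxyphenyl in place of 2-chloro-6-(trifluoromethyl)phenyl on an aromatic carbon of the shared core (2-fluoro-6-methoxyphenyl in place of 2-chloro-6-(trifluoromethyl)phenyl on an aromatic carbon). Among the measured compounds shown here, no measured step yet sizes this change, so the expectation rests on compound 2 at 65.1 ug/mL, with no shift beyond the scatter in this assay. The expected step is small and slightly upward, a 1.1-fold higher number from compound 2 to compound 3 (0.04 log units; within the scatter). For compound 3 the estimated value is 72 ug/mL, with an expected range of 42 ug/mL to 95 ug/mL.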

Compound 3, solubility: > 74 ug/mL
Compound 3: a limit, no number; the forecaster's own chance of this, stated with the estimate: 40%; middle value at least 1.0-fold (0.01 log units) from the limit.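

Among these compounds, the first step at this position replaces 2-chloro-6-(trifluoromethyl)phenyl with 2-fluoro-6-methoxyphenyl on an aromatic carbon of the shared core, and in this assay it gives an at least 1.1-fold higher number from compound 2 to compound 3 (0.05 log units; that floor lies within the scatter). The change therefore shows no loss on this read-out, though only a floor is established. The reading for compound 3 is a limit and not a number: the limit of > 74 ug/mL in this assay, at which 1 of the 3 values shown sits.

Going by these compounds, the true size of the step stays open, as does any ranking of the two aryl groups. Also open, on these data alone, is how a carboxylic acid or an aminomethyl group in place of the methoxy would read in this assay.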